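Swapping the Aryl Ring on a Chalcone Amide

This account rests on a few compounds, and the source may have more. Where it says the series, first, only, none or still open, it means among the compounds named here.

Measured so far:
compound 1, `CC(C)(C)c1ccc(/C=C/C(=O)c2ccc(OCC(=O)N[C@H]3CCOC3=O)cc2)cc1`, gives 6570 nM
compound 2, `O=C(CNc1ccccc1Cl)N[C@H]1CCOC1=O`, gives > 64000 nM
compound 3, `O=C(CNc1ccc(F)cc1)N[C@H]1CCOC1=O`, gives > 64000 nM

Of the compounds shown here, three have been tested in a functional assay on DU-145 cells (Homo sapiens) for antiproliferative activity, read by MTT assay, with a stated time of 72 h; a lower number here means a stronger inhibitor, a higher number a weaker inhibitor. Compound 1 is the only one of them to return an actual number: in this assay compound 1 gives 6570 nM. For compound 2 the result is not a number but a limit of the assay, > 64000 nM. For compound 3 the result is likewise only a limit, > 64000 nM. For the measured compounds named here, compound 1 therefore stands on its own as the sole numerical value, while the other two results sit at the limit of > 64000 nM in this assay, at which 2 of the 3 values shown sit. Going by the values given here, no pair of measured compounds differs in just one place, so no single structural step has been quantified here.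

Compound 4, `O=C(COc1ccc(C(=O)/C=C/c2cccc(F)c2)cc1)N[C@H]1CCOC1=O`, has not yet been measured. It keeps the whole shared core of compound 1 and differs only in one group: 3-fluorophenyl in place of 4-(tert-butyl)phenyl on a double-bonded chain carbon bound to a double-bonded chain carbon. Among the compounds with values here, nothing among the measured compounds tracks this particular exchange, so its effect has to be estimated rather than read off. The expectation is a moderate weakening, a step of a 2.3-fold higher number from compound 1 to compound 4 (0.36 log units; beyond the scatter), large enough to clear the usual scatter but not dramatic. Compound 4 is thus expected to give about 15000 nM, with a likely range from 5000 nM to 45000 nM.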

Compound 4, half-maximal inhibitory concentration: 17200 nM
Beside the measured number, compound 4's estimate is 1.1-fold (0.06 log units) below it; the range from low to high includes it.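

In this assay, for the compounds shown here, the exchange of 4-(tert-butyl)phenyl for 3-fluorophenyl on a double-bonded chain carbon bound to a double-bonded chain carbon is the first single change that can be read, and it comes out as a 2.6-fold higher number from compound 1 to compound 4 (0.42 log units; beyond the scatter) in a step that is modest in size. This shows that the group at this position matters to the read-out, yet a change that takes out 10 heavy atoms and puts in 7 does not remove the activity altogether, for compound 4 gives 17200 nM. Nothing given here accounts for the size of this step.

The compounds shown leave open whether the weaker number goes with losing the tert-butyl group, with gaining the fluorine or with the different place of each on the ring, as all of these changed in one exchange. Unsubstituted phenyl, 4-fluorophenyl or 3-(tert-butyl)phenyl at this position would pull these apart, and a pyridine ring or a methoxy-bearing phenyl would show how far the position tolerates other kinds of group.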